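Cyano in Place of Methylsulfonyl: Expected Half-Life

The compounds below may be only part of what the source reports. "The series", "measured", "known", "first", "only" and "open" are said of these compounds alone.

Measured so far:
compound 1, `NS(=O)(=O)CC(=O)NCCSc1nonc1/C(=N/O)Nc1cccc(C(F)F)c1`: > 3 h
compound 2, `CS(=O)(=O)CC(=O)NCCSc1nonc1/C(=N/O)Nc1ccc(F)c(C(F)F)c1`: 1.59 h

Of the compounds shown here, two have been measured in an ADME assay on isolated protein for pharmacokinetics, with UDP-glucuronosyltransferase 1A9 (Homo sapiens) as the target, read by LC-MS, with a stated time of 60 min, at 37 degrees C, tested at 1 uM, in the presence of a further agent that is not named here; a higher number here means that the compound lasts longer, a lower number that the compound disappears faster. Compound 1 does not give a number in this assay but only (the limit of > 3 h in this assay, at which 1 of the 2 values shown sits). Among the compounds with values here, compound 2 gives 1.59 h in this assay, the only number among the values shown. Within the data shown here, no step between measured compounds that differ in one place is available, so nothing measured bears directly on the change considered here.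

Compound 3 `N#CCC(=O)NCCSc1nonc1/C(=N/O)Nc1ccc(F)c(C(F)F)c1` differs from compound 2 in one place: cyano in place of methylsulfonyl on a saturated chain carbon bound to a carbonyl carbon. Among the measured compounds shown here, with no measured step to lean on, the step from compound 2 to compound 3 in this assay is expected to be small, a 1.0-fold higher number from compound 2 to compound 3 (0.00 log units; within the scatter), and no change beyond the usual scatter is expected in either direction. Compound 3 is therefore expected to give 1.6 h in this assay, with a range from 0.8 h to 3.2 h.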

Compound 3, half-life: 1.73 h
For compound 3 the middle estimate is 1.1-fold (0.03 log units) below the measured one, within the range that was stated.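

In this assay, cyano in place of methylsulfonyl on a saturated chain carbon bound to a carbonyl carbon gives a 1.1-fold higher number from compound 2 to compound 3 (0.04 log units; within the scatter). Within the data shown here, this is the first step measured at this position, and it shows that a methylsulfonyl of 4 heavy atoms and 2 hydrogen-bond acceptors can give way to a cyano of 2 heavy atoms and 1 hydrogen-bond acceptor without a change beyond the scatter. Nothing available bears on a cause for this result.

On these data alone, whether the same holds at this place for an amine, a carboxylic acid or a longer chain stays open. Compound 1 gives no number but a limit and differs from the other compounds in more than one place, so no step to it can be read: the limit of > 3 h in this assay, at which 1 of the 3 values shown sits.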